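This account rests on a few compounds, and the source may have more. Where it says the series, first, only, none or still open, it means among the compounds named here.

Compound 1 `C/C(=N/NC(=S)Nc1cccc(F)c1)c1ccccn1`: 18 nM
Compound 2 `C/C(=N\NC(=S)Nc1ccccc1)c1ccccn1`: 1.4 nM
Compound 3 `C/C(=N/NC(=S)Nc1ccc(I)cc1)c1ccccn1`: 59 nM

All three share one core and differ in what sits on the outer ring. In a functional assay on U-87MG ATCC cells (Homo sapiens) for cytotoxicity, read by MTT assay, with a stated time of 48 h (a higher number here means a weaker inhibitor, a lower number a stronger inhibitor), compound 3 gives the highest number of the three, making it the weakest inhibitor among them; its nearest neighbour is compound 1, and the gap to compound 2 is the widest. Compound 4 `C/C(=N/NC(=S)Nc1ccccc1)c1ccccn1` has not yet been measured. It differs from compound 3 in a single place: hydrogen in place of iodo on an aromatic carbon. Among the measured compounds shown here, no measured pair isolates exactly this change, so the step cannot be read off directly. Compound 2, which also carries no halogen on that ring, gives 1.4 nM in this assay. On that basis the step from compound 3 to compound 4 is expected to lower the number well beyond the scatter, by about a 12-fold lower number from compound 3 to compound 4 (1.07 log units; beyond the scatter). Compound 4 is therefore estimated at 5 nM, with a likely range from 1.2 nM to 25 nM.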

Compound 4, half-maximal inhibitory concentration: 1.4 nM
The estimate for compound 4 lay 3.6-fold (0.55 log units) above the measured number, within the range that was stated.
By their numbers in this assay, from the lowest: compounds 2 and 4 (each within the scatter of the next); then compound 1; then compound 3.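

In this assay, the outer ring without a halogen gives much lower numbers than either halogen-bearing ring: replacing iodo with hydrogen gives a 42-fold lower number from compound 3 to compound 4 (1.62 log units; beyond the scatter), and replacing fluoro with hydrogen gives a 13-fold lower number from compound 1 to compound 4 (1.11 log units; beyond the scatter). These two steps show that, in compounds 1, 3 and 4, hydrogen gives the lowest number. The drawn forms of the double bond show no change at the digits printed from compound 2 to compound 4 (within the scatter), a comparison that isolates one feature alone: the fact that compounds 2 and 4 differ only in the configuration as drawn

The compounds shown leave open whether iodo and fluoro would read alike on the same ring carbon. Going by these compounds, how an amine or a methoxy group there would compare with hydrogen also remains open.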